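Working notes: ethoxycarbonyl to methoxycarbonyl in the series

A few compounds are considered here, and "the series" means these few. Any claim that something is new, unique, unknown or untested is made for them only; others in the source may bear on it.

Compound 1 `CC#CCn1c(N2CCC[C@@H](N)C2)nc2c1c(=O)n(Cc1ccc(Cl)cc1C(=O)O)c(=O)n2C`: 13.7 mL/min/kg
Compound 2 `CC#CCn1c(N2CCC[C@@H](N)C2)nc2c1c(=O)n(Cc1ccc(Cl)cc1C(=O)OCC)c(=O)n2C`: 3.83 mL/min/kg

In an ADME assay on the whole organism (Rattus norvegicus, strain Sprague-Dawley) for pharmacokinetics, read by LC-MS, with a stated time of 48 h, at a dose of 10 mg/kg by the oral route (on this read-out lower numbers stand for slow clearance and higher numbers for fast clearance), compound 2 holds the lower of the two numbers at 3.83 mL/min/kg, while compound 1 gives 13.7 mL/min/kg. The next compound to be read is compound 3 `CC#CCn1c(N2CCC[C@@H](N)C2)nc2c1c(=O)n(Cc1ccc(Cl)cc1C(=O)OC)c(=O)n2C`, which differs from compound 2 by hydrogen in place of methyl on a saturated chain carbon bound to an oxygen next to a carbonyl group, so that ethoxycarbonyl becomes methoxycarbonyl.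

Among the compounds with values here, only one measured step bears on this change: a 3.6-fold lower number from compound 1 to compound 2 (0.55 log units; beyond the scatter), with ethyl in place of hydrogen on an oxygen next to a carbonyl group. That step takes the oxygen from bare hydrogen to a full ethyl, whereas the present change leaves a methyl on it. Within the data shown here, no measured pair compares ethyl with methyl directly, so the evidence is thin. In this assay no shift beyond the scatter is expected, with any small movement more likely upward, toward compound 1. The expected step is a 1.3-fold higher number from compound 2 to compound 3 (0.10 log units; within the scatter). The estimate for compound 3 is 4.8 mL/min/kg, with an expected range of 2.2 mL/min/kg to 10 mL/min/kg.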

Compound 3, clearance: 2.67 mL/min/kg
Estimate against measurement, compound 3: 1.8-fold (0.25 log units) above; the measured number falls inside the stated range.
By their numbers in this assay, from the lowest: compounds 3 and 2 (each within the scatter of the next); then compound 1.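

In this assay the change from ethoxycarbonyl to methoxycarbonyl gives a 1.4-fold lower number from compound 2 to compound 3 (0.16 log units; within the scatter) and so does not separate these two groups on clearance. Within the data shown here, this is the first direct comparison of ethyl with methyl on this oxygen, and the size of the chain on it makes no difference that can be read across this pair. Placing methyl rather than hydrogen on the same oxygen gives a 5.1-fold lower number from compound 1 to compound 3 (0.71 log units; beyond the scatter) in the same direction as the earlier step with ethyl, a 3.6-fold lower number from compound 1 to compound 2 (0.55 log units; beyond the scatter) and thus the separation from the carboxylic acid does not require the full ethyl, since methyl is enough in this pair. Nothing measured here accounts for either the separation from the carboxylic acid or the lack of one between ethyl and methyl.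

As far as these compounds go, whether this flat reading extends to a longer chain such as propyl, or to a branched group such as isopropyl or tert-butyl on the same oxygen, stays open. Also open, from the compounds shown here alone, is whether a primary amide in place of the ester group would track with the esters or with the carboxylic acid.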